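Fluoro for methoxy on the shared core

A few compounds are considered here, and "the series" means these few. Any claim that something is new, unique, unknown or untested is made for them only; others in the source may bear on it.

Measured so far:
compound 1 `COc1ccc(/C=C/c2cc(OC)cc(OC)c2/C=C/C(=O)c2cc3cc(OC)ccc3oc2=O)cc1` — in an assay on isolated protein for inhibition of Amine oxidase [flavin-containing] A (Homo sapiens), read by fluorescence, with a stated time of 15 min (a higher number here means a weaker inhibitor, a lower number a stronger inhibitor), compound 1 gives > 60000 nM, a limit of the assay.
compound 2 `COc1ccc(/C=C/c2cc(OC)cc(OC)c2/C=C/C(=O)c2cc3cc(Br)ccc3oc2=O)cc1` — in this assay compound 2 gives 12100 nM.

Compound 1 stands only at a limit (the limit of > 60000 nM in this assay, at which 1 of the 2 values shown sits); no number is known for it. Going by the values given here, the single measured step is an at least 4.9-fold lower number from compound 1 to compound 2 (0.69 log units; beyond the scatter), bromo in place of methoxy on an aromatic carbon. Compound 3 `COc1ccc(/C=C/c2cc(OC)cc(OC)c2/C=C/C(=O)c2cc3cc(F)ccc3oc2=O)cc1` carries a related change: fluoro in place of methoxy on an aromatic carbon. Since bromo in place of methoxy gave a lower number in an at least 4.9-fold lower number from compound 1 to compound 2 (0.69 log units; beyond the scatter), fluoro in place of methoxy is expected to move in the same direction, though the size is uncertain with one step to lean on, and compound 3 may well remain at the limit. The expected step is an at least 2.0-fold lower number from compound 1 to compound 3 (0.30 log units; that floor lies within the scatter). Compound 3 is estimated at 30000 nM, with a range from 10000 nM to 60000 nM.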

Compound 3, half-maximal inhibitory concentration: 44300 nM
Compound 3: middle estimate off by 1.5-fold (0.17 log units), on the low side; the range from low to high includes it.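

On this aromatic carbon, fluoro in place of bromo gives a 3.7-fold higher number from compound 2 to compound 3 (0.56 log units; beyond the scatter), so in this assay the two halogens are separated at this position. Fluoro in place of methoxy gives an at least 1.3-fold lower number from compound 1 to compound 3 (0.13 log units; that floor lies within the scatter), and this floor alone does not separate fluoro from methoxy. The true size of that step stays unknown because compound 1 stands at a limit: the limit of > 60000 nM in this assay, at which 1 of the 3 values shown sits.

Still open, as far as these compounds go, is whether chloro or iodo at this place would fall in line with the gap between bromo and fluoro, and whether a nitrile, an amine or a carboxylic acid there would give a lower number than compound 2 does. Also open is what the methoxy groups elsewhere on the shared core contribute, as all the compounds shown carry them.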